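Swapping one fluoro for hydrogen on compound 1

The source may report more compounds than this note shows. Statements on the series, on what has been measured and on what is new or still open speak of the compounds shown alone.

Among the measured compounds shown here, in an ADME assay for permeability, using PAMPA, at pH 5.5 (on this read-out lower numbers stand for lower permeability and higher numbers for higher permeability), compound 1 `Cn1cc(-c2ccc(C(F)(F)F)cc2)c2cc(F)c(C(=O)NS(=O)(=O)C3CC3)cc21` gives 1660 nm/s and so holds the highest number of the three compounds measured so far. Compound 2 `CC(C)COc1ccc(-c2nn(C)c3cc(C(=O)NS(=O)(=O)C4CC4)c(F)cc23)cn1` gives 762 nm/s and compound 3 `Cn1nc(-c2ccc(C(F)(F)F)cc2)c2cc(F)c(C(=O)NS(=O)(=O)C3CC3)cc21` gives 592 nm/s here, and compound 1 sits above each of them by more than the usual scatter between repeated measurements.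

Compound 4 `Cn1cc(-c2ccc(C(F)(F)F)cc2)c2ccc(C(=O)NS(=O)(=O)C3CC3)cc21` has not been measured yet. It comes from compound 1 by a single small edit: hydrogen in place of fluoro on an aromatic carbon with hydrogen in place of fluoro on an aromatic carbon. Everything else in the structure stays as it is.

For the measured compounds named here, none of the measured compounds shows what this particular swap does, so no direct precedent exists and the expectation has to stay cautious. For a change this small, the expected step in this assay is a slight drop that does not go beyond the scatter. Compound 1 at 1660 nm/s serves as the starting point for that expectation. The estimated change is a modest one a 1.3-fold lower number from compound 1 to compound 4 (0.11 log units; within the scatter) and it lies within the usual scatter. The estimate for compound 4 is 1300 nm/s with an expected range from 650 nm/s to 2400 nm/s as the likely span.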

Compound 4, apparent permeability: 525 nm/s
Compound 4: the middle estimate sits 2.5-fold (0.39 log units) above what was measured, outside the stated range (below it).
By their numbers in this assay, from the lowest: compounds 4, 3 and 2 (each within the scatter of the next); then compound 1.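

Among the compounds shown here, this is the first pair of compounds that isolates the aromatic carbon ortho to the (cyclopropylsulfonyl)carbamoyl group, and it shows that the change at this one spot is not silent in this assay: hydrogen in place of fluoro gives a 3.2-fold lower number from compound 1 to compound 4 (0.50 log units; beyond the scatter). A single fluorine, with the rest of the structure untouched, is therefore enough to move this read-out by more than the usual scatter, and the direction in this pair favours keeping the fluoro. The measurements shown give no independent information on why removing this atom has such an effect, so the reason for the step remains unknown.

Only fluoro and hydrogen are shown at this position, so it remains open whether a chlorine atom, a methyl group or a nitrile would give a number closer to that of compound 1 or of compound 4. It also remains open whether the same swap would produce a similar step on compound 2 or compound 3, which carry the fluoro on a different shared core and have no hydrogen partner among the compounds shown.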